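The compounds below may be only part of what the source reports. "The series", "measured", "known", "first", "only" and "open" are said of these compounds alone.

Compound 1 `O=C(Nc1cccc(-c2ccc(CO)cc2)c1)c1ccccc1` gives < 10% in an assay for binding affinity to 17-beta-hydroxysteroid dehydrogenase type 2 (Homo sapiens), with a stated time of 20 min, tested at 1 uM (a lower number here means less inhibition, a higher number more inhibition at the concentration tested (going by the name of the read-out)), which is a limit of the assay and not a number. Compound 2 `CS(=O)(=O)Nc1ccc(-c2ccc(CO)cc2)cc1` gives < 10% in this assay, again a limit. Compound 3 `O=C(Nc1cccc(-c2ccc(O)cc2)c1)c1ccccc1` gives < 10% in this assay, also a limit.

Compound 3 differs from compound 1 by one change, (hydroxy in place of hydroxymethyl on an aromatic carbon). The step it made, a step that the two limits leave unreadable from compound 1 to compound 3, cannot be sized because the limit of < 10% in this assay, at which 3 of the 3 values shown sit, holds both ends of it. The cores of compound 1 and compound 2 differ in more than one place, and that difference is not broken down here.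

Compound 4 `CS(=O)(=O)Nc1ccc(-c2ccc(O)cc2)cc1` is not yet measured. It differs from compound 2 by hydroxy in place of hydroxymethyl on an aromatic carbon, the same change that turns compound 1 into compound 3. Since that change left compound 3 at the limit, and compound 2 itself sits at the limit, the expected step that the limit leaves unreadable from compound 2 to compound 4 is essentially nothing visible. Compound 4 is therefore estimated at 5% in this assay, most likely again reported only as a limit, with a range from 0% to 15%.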

Compound 4, a percentage reported as inhibition, at one concentration (the size of the read-out at that concentration, not a potency): < 10%
Compound 4 gave a limit, no number (the forecaster's own chance of this, stated with the estimate: 85%); the middle value does not contradict the limit.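

The step from compound 2 to compound 4 cannot be sized, because both ends are a limit and not a number: the limit of < 10% in this assay, at which 4 of the 4 values shown sit.

The compounds shown leave open whether hydroxy in place of hydroxymethyl changes inhibition at all, and which change to these structures would give a readable number in this assay.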